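The source may report more compounds than this note shows. Statements on the series, on what has been measured and on what is new or still open speak of the compounds shown alone.

Working notes on the series. Compound 1 `CC1=C(C(=O)Nc2ccc([N+](=O)[O-])cc2)C(c2ccc(Br)cc2)N=C(SCc2ccccc2Cl)N1`, compound 2 `CC1=C(C(=O)Nc2ccc([N+](=O)[O-])cc2)C(c2ccc(Br)cc2)N=C(SCc2cccc(Cl)c2)N1` and compound 3 `CC1=C(C(=O)Nc2ccc([N+](=O)[O-])cc2)C(c2ccc(Br)cc2)N=C(SCc2ccc(F)cc2)N1` share one core and differ only in the group on the saturated chain carbon bound to a sulfur. In a functional assay on the whole organism (artery, strain albino) with Rattus norvegicus as the target, with a stated time of 360 min, at a dose of 10 mg/kg by the oral route (a lower number here means less inhibition, a higher number more inhibition at the dose given (going by the name of the read-out)), compound 1 gives 13.9%, compound 2 gives 7.2% and compound 3 gives 38.7%; compound 1 stands second highest of the three. Steps: a number 6.7 percentage points lower from compound 1 to compound 2 (within the scatter); a number 24.8 percentage points higher from compound 1 to compound 3 (beyond the scatter); a number 31.5 percentage points higher from compound 2 to compound 3 (beyond the scatter).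

Compound 4 `CC1=C(C(=O)Nc2ccc([N+](=O)[O-])cc2)C(c2cccc([N+](=O)[O-])c2)N=C(SCc2ccccc2Cl)N1` changes a different place: 3-nitrophenyl in place of 4-bromophenyl on a saturated ring carbon. Within the data shown here, no measured step alters this saturated ring carbon, so none bears directly on it, and the measured steps give no direction for the change. For compound 4 the expectation is therefore no step beyond the scatter, a number 2.1 percentage points higher from compound 1 to compound 4 (within the scatter), with a wide range. Compound 4 is estimated at 16%, between 2% and 38%.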

Compound 4, a percentage reported as inhibition, in the whole organism at one dose (the size of the read-out at that dose, not a potency): 17.5%
For compound 4 the middle estimate is 1.5 percentage points below the measured one, within the range that was stated.
By their numbers in this assay, from the lowest: compounds 2, 1 and 4 (each within the scatter of the next, the first and the last beyond it); then compound 3.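

Among these compounds, the saturated ring carbon is varied here for the first time: in this assay, with the 2-chlorophenyl group on the sulfur chain held fixed, the exchange gives a number 3.6 percentage points higher from compound 1 to compound 4 (within the scatter). Compound 1 and compound 4 therefore cannot be told apart, although the entering 3-nitrophenyl differs from 4-bromophenyl in heavy atoms and hydrogen-bond acceptors. No evidence bears on the reason for this result.

Open, from the compounds shown here alone, is whether an amine or a carboxylic acid on this phenyl ring would leave the number equally undisturbed. Also open, going by these compounds, is whether 3-nitrophenyl at this carbon would hold alongside the 4-fluorophenyl group of compound 3.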